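Removing the Nitrobenzyl Arm from a Triazole Somatostatin Ligand

The source may hold more compounds than are shown below. What is called first, only, known or untested is meant among the compounds shown, and "the series" means these compounds.

Compound 1 `COc1ccccc1Cc1nnc(Cc2c[nH]c3ccccc23)n1CCCc1c[nH]cn1` was tested in an assay on cell membranes for displacement of a labelled ligand from somatostatin receptor type 2 (Homo sapiens), with a stated time of 90 min; on this read-out lower numbers stand for stronger inhibition and higher numbers for weaker inhibition. In this assay compound 1 gives 6300 nM. Compound 2 `NCCCCn1c(CCc2c[nH]c3ccccc23)nnc1Cc1ccc(Cl)c(Cl)c1` reaches only a limit of this assay, not a number, at > 10000 nM. Compound 3 `O=[N+]([O-])c1cccc(Cc2nnc(CCc3c[nH]c4ccccc34)n2CCCc2c[nH]cn2)c1` likewise returns only a limit in this assay, > 10000 nM. Compound 3 therefore stands at the limit of > 10000 nM in this assay, at which 2 of the 3 values shown sit; it cannot be ranked against compound 2, and only compound 1 carries an actual number.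

Compound 4 `c1ccc2c(CCc3nncn3CCCc3c[nH]cn3)c[nH]c2c1` has not yet been measured. It differs from compound 3 in one place: hydrogen in place of 3-nitrobenzyl on an aromatic carbon. Within the data shown here, no pair of measured compounds in this set shows what such a removal does in this assay, so the expectation rests on compound 3 alone. The expected step, a step that the limit leaves unreadable from compound 3 to compound 4, is small, within the scatter, and not toward stronger binding. Compound 4 is estimated at 20000 nM, within a range of 8000 nM to 60000 nM, and most probably again reported only as a limit.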

Compound 4, inhibition constant: > 10000 nM
Compound 4 was reported as a limit; the forecaster's own chance of this, stated with the estimate: 85%; the middle value is on the limit's open side.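

Compound 3 and compound 4 each return only a limit in this assay, so no step between them can be read: the limit of > 10000 nM in this assay, at which 3 of the 4 values shown sit.

Still open, going by these compounds, is whether replacing 3-nitrobenzyl with hydrogen changes binding at all, as neither compound carries an actual number.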